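From allyl to methyl: compound 3 to compound 4

The compounds below may be only part of what the source reports. "The series", "measured", "known", "first", "only" and "open" are said of these compounds alone.

Compound 1 `O=C1Nc2ccccc2/C1=N/NC(=S)Nc1ccccc1`: 1470 nM
Compound 2 `O=C1Nc2ccccc2/C1=N/NC(=S)Nc1cccnc1`: > 50000 nM (a limit of the assay)
Compound 3 `C=CCNC(=S)N/N=C1\C(=O)Nc2ccccc21`: 20700 nM

In a functional assay on KB-V1 cells (Homo sapiens) for cytotoxicity, read by MTT assay, with a stated time of 72 h (a higher number here means a weaker inhibitor, a lower number a stronger inhibitor), compound 3 holds the higher of the two exact numbers, at 20700 nM. Compound 4 `CNC(=S)N/N=C1\C(=O)Nc2ccccc21` turns its allyl into methyl, with hydrogen in place of vinyl on a saturated chain carbon bound to an amide-type nitrogen. For the measured compounds named here, no measured step makes this change, but three alter the group on that nitrogen. Allyl in place of phenyl gave a 14-fold higher number from compound 1 to compound 3 (1.15 log units; beyond the scatter). Pyridin-3-yl in place of phenyl gave an at least 34-fold higher number from compound 1 to compound 2 (1.53 log units; beyond the scatter). Allyl in place of pyridin-3-yl gave an at least 2.4-fold lower number from compound 2 to compound 3 (0.38 log units; beyond the scatter). None of these steps removes vinyl, so only a small rise, within the scatter, is expected: a 1.4-fold higher number from compound 3 to compound 4 (0.16 log units; within the scatter). Compound 4 is estimated at 30000 nM, with an expected range from 10000 nM to 50000 nM.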

Compound 4, half-maximal inhibitory concentration: 19400 nM
Estimate against measurement, compound 4: 1.5-fold (0.19 log units) above; the measured number falls inside the stated range.
By their numbers in this assay, from the lowest: compound 1; then compounds 4 and 3 (each within the scatter of the next). At a limit, above all of these: compound 2.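

With vinyl gone, the group on this nitrogen shows no difference beyond the scatter (a 1.1-fold lower number from compound 3 to compound 4 (0.03 log units; within the scatter)), while methyl, like allyl, stays far from phenyl (a 13-fold higher number from compound 1 to compound 4 (1.12 log units; beyond the scatter)). Methyl also gives a lower number than pyridin-3-yl (an at least 2.5-fold lower number from compound 2 to compound 4 (0.41 log units; beyond the scatter)). The value of compound 2 is a limit, not a number: the limit of > 50000 nM in this assay, at which 1 of the 4 values shown sits.

The compounds shown leave open whether a longer chain such as butyl, or a benzyl group, on this nitrogen would come closer to phenyl. They also leave open what a methoxy group on the phenyl ring would do.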